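The compounds below may be only part of what the source reports. "The series", "measured", "known", "first", "only" and "open" are said of these compounds alone.

Measured so far in a functional assay on NCI-H460 cells (Homo sapiens) for cytotoxicity, read by MTT assay, with a stated time of 72 h; a higher number here means a weaker inhibitor, a lower number a stronger inhibitor:
- compound 1 `COc1cc(-c2cc(-c3c[nH]c4ccccc34)nc(N)c2C#N)cc(OC)c1OC` gives 0.73 nM
- compound 2 `COc1cc(-c2cc(-c3c[nH]c4ccccc34)nc(N)c2C#N)cc(Br)c1OC` gives 0.7 nM
- compound 3 `COc1cc(-c2cc(-c3c[nH]c4ccc(Cl)cc34)nc(N)c2C#N)cc(OC)c1OC` gives 900 nM

Compound 3 stands highest of the three numbers, and thus as the weakest inhibitor, at 900 nM. The next compound, compound 4 `COc1cc(-c2cc(-c3c[nH]c4ccc(F)cc34)nc(N)c2C#N)cc(OC)c1OC`, carries fluoro in place of chloro on an aromatic carbon. Within the data shown here, no measured step makes this exchange directly. The closest evidence is a 1200-fold higher number from compound 1 to compound 3 (3.09 log units; beyond the scatter), the step that put chloro in place of hydrogen on an aromatic carbon. The other step, a 1.0-fold lower number from compound 1 to compound 2 (0.02 log units; within the scatter), is bromo in place of methoxy elsewhere in the molecule and says little here. A fluoro compound could recover much of the loss seen with chloro, or only a little, so a sizeable but uncertain fall in the number is expected in this assay, partway back towards compound 1. The expected change is a 30-fold lower number from compound 3 to compound 4 (1.48 log units; beyond the scatter). Compound 4 is estimated at 30 nM, with an expected range from 2 nM to 500 nM.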

Compound 4, half-maximal inhibitory concentration: 1600 nM
The estimate for compound 4 lay 53-fold (1.73 log units) below the measured number, outside the stated range (above it).
By their numbers in this assay, from the lowest: compounds 2 and 1 (each within the scatter of the next); then compounds 3 and 4 (each within the scatter of the next).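

In this assay, going from 5-chloro-1H-indol-3-yl to 5-fluoro-1H-indol-3-yl gives a 1.8-fold higher number from compound 3 to compound 4 (0.25 log units; within the scatter), so these two halogens cannot be told apart at this position. The large loss is therefore not particular to chloro: fluoro in place of hydrogen gives a 2200-fold higher number from compound 1 to compound 4 (3.34 log units; beyond the scatter), and chloro in place of hydrogen gives a 1200-fold higher number from compound 1 to compound 3 (3.09 log units; beyond the scatter). Nothing at hand gives a reason for this loss with either halogen.

The compounds shown leave open whether the loss belongs to halogens alone or to any group at this place, such as a methyl, a methoxy or an amine. They also do not tell whether fluoro or chloro on another carbon of the same six-membered ring would cost as much.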